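The source may report more compounds than this note shows. Statements on the series, on what has been measured and on what is new or still open speak of the compounds shown alone.

Measured so far:
compound 1 `NC(=O)CCc1c[nH]c2c(F)cccc12` — 64 nM
compound 2 `NCC(N)CCc1c[nH]c2ccc(F)cc12` — 26 nM

In an assay on isolated protein for inhibition of Myeloperoxidase (Homo sapiens), read by ELISA, with a stated time of 5 min (on this read-out higher numbers stand for weaker inhibition and lower numbers for stronger inhibition), compound 2 gives 26 nM, the lower of the two numbers; compound 1 gives 64 nM, a gap beyond the usual scatter. Compound 3 `NC(=O)CCCc1c[nH]c2ccc(F)cc12` is not yet measured. It differs from compound 2 by carbamoylmethyl in place of 1,2-diaminoethyl on a saturated chain carbon, two bonds along the chain from an aromatic carbon. Among the measured compounds shown here, no pair of measured compounds differs in one place alone, so the effect of this change has not been observed directly. The expected step in this assay from compound 2 to compound 3 is a 2.3-fold higher number from compound 2 to compound 3 (0.36 log units; beyond the scatter), toward a weaker number, roughly at the edge of the scatter. Compound 3 is estimated at 60 nM, range 20 nM to 200 nM.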

Compound 3, half-maximal inhibitory concentration: 18 nM
The estimate for compound 3 lay 3.3-fold (0.52 log units) above the measured number; the measured number lies below the stated range.
By their numbers in this assay, from the lowest: compounds 3 and 2 (each within the scatter of the next); then compound 1.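

In this assay, carbamoylmethyl in place of 1,2-diaminoethyl on a saturated chain carbon, two bonds along the chain from an aromatic carbon, gives a 1.4-fold lower number from compound 2 to compound 3 (0.16 log units; within the scatter). At this position, the two groups are therefore not separated by this read-out, and the 1,2-diaminoethyl group is not needed to keep the number of compound 2. No available data account for this outcome. Open, as far as these compounds go, is whether a carboxylic acid, a single primary amine or a longer chain at this position would also stay within the scatter of compound 3.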